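Series notes: replacing tert-butoxy by amino at the biaryl tail

This account rests on a few compounds, and the source may have more. Where it says the series, first, only, none or still open, it means among the compounds named here.

Measured so far:
compound 1 `CC(C)C[C@H](N)CN(C(=O)C(C)Cc1ccccc1)c1ccc(-c2ccccc2)cc1` 1.2 nM
compound 2 `CC[C@H](C)[C@H](N)CN(C(=O)[C@@H]1C[C@H]1c1ccccc1)c1ccc(-c2ccc(COC)cc2)cc1` 35 nM
compound 3 `CC[C@H](C)[C@H](N)CN(C(=O)[C@@H]1C[C@H]1c1ccccc1)c1ccc(-c2ccc(COC(C)(C)C)cc2)cc1` 280 nM

In a functional assay for agonist activity at G protein-coupled receptor 88 (Homo sapiens), read by HTRF and cAMP accumulation (on this read-out lower numbers stand for an effect already at smaller amounts and higher numbers for an effect only at larger amounts of compound), compound 3 gives the highest of the three numbers; compound 2 lies nearest, compound 1 furthest. The next compound is compound 4 `CC[C@H](C)[C@H](N)CN(C(=O)[C@@H]1C[C@H]1c1ccccc1)c1ccc(-c2ccc(CN)cc2)cc1`. The change from compound 3 is amino in place of tert-butoxy on a saturated chain carbon bound to an aromatic carbon. Going by the values given here, the only step that bears on it is an 8.0-fold higher number from compound 2 to compound 3 (0.90 log units; beyond the scatter), which shows a smaller group on the oxygen with a lower number. Among the compounds with values here, since the tert-butoxy now leaves altogether, a lower number is expected, though amino in place of an oxygen-bound group has no measured precedent here, so the size is uncertain. Compound 4 is estimated at 60 nM, range 12 nM to 300 nM, a step of a 4.7-fold lower number from compound 3 to compound 4 (0.67 log units; beyond the scatter) expected.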

Compound 4, half-maximal effective concentration: > 30000 nM
Compound 4 ended at the assay's limit; the forecaster's own chance of this, stated with the estimate: 5%; at least 500-fold (2.69 log units) between middle value and limit.
By their numbers in this assay, from the lowest: compound 1; then compound 2; then compound 3. At a limit, above all of these: compound 4.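

In this assay compound 4 stands at a limit, not a number, > 30000 nM. Among the ethers, the change at this saturated chain carbon bound to an aromatic carbon gave an 8.0-fold higher number from compound 2 to compound 3 (0.90 log units; beyond the scatter), whereas amino gives an at least 100-fold higher number from compound 3 to compound 4 (2.02 log units; beyond the scatter) and an at least 850-fold higher number from compound 2 to compound 4 (2.93 log units; beyond the scatter). Going by these compounds alone, the link between a smaller group and a lower number seen in compound 2 and compound 3 therefore does not extend to amino, the one group here with a hydrogen-bond donor.

Whether the oxygen's absence or the amine itself accounts for this stays open. A hydroxyl, a dimethylamino or an acetamide at this place would separate the two.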